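Bromo in Place of Nitro on the Shared Core

The compounds below may be only part of what the source reports. "The series", "measured", "known", "first", "only" and "open" are said of these compounds alone.

Of the compounds shown here, three have been tested in a functional assay on MCF7 cells (Homo sapiens) for cytotoxicity, read by MTT assay, with a stated time of 24 h; a higher number here means a weaker inhibitor, a lower number a stronger inhibitor. Compound 1 `Nc1ccc2sc(NC(=S)NC(=O)c3ccccc3)nc2c1` gives 38600 nM and compound 3 `Nc1ccc2sc(NC(=S)NC(=O)c3ccc([N+](=O)[O-])cc3)nc2c1` gives 33200 nM. The step of a 1.2-fold lower number from compound 1 to compound 3 (0.07 log units; within the scatter) adds a nitro group and stays within the scatter. Compound 2 `CCCCC(=O)NC(=S)Nc1nc2cc([N+](=O)[O-])ccc2s1` sits at the limit of > 100000 nM in this assay, at which 1 of the 3 values shown sits, so for compound 2 the result > 100000 nM is a limit of the assay rather than a number. Compound 4 `CCCCC(=O)NC(=S)Nc1nc2cc(Br)ccc2s1` differs from compound 2 by bromo in place of nitro on an aromatic carbon. Going by the values given here, the only measured step, from compound 1 to compound 3, also concerns a nitro group and stayed within the scatter, which suggests the swap in compound 4 may shift the number little in this assay. Compound 4 is therefore expected near 100000 nM, between 40000 nM and 250000 nM. The step of a number no higher from compound 2 to compound 4 (the limit leaves the size open) is thus an estimate, not a measurement.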

Compound 4, half-maximal inhibitory concentration: 45700 nM
Estimate against measurement, compound 4: 2.2-fold (0.34 log units) above; the measured number falls inside the stated range.
By their numbers in this assay, from the lowest: compounds 3, 1 and 4 (each within the scatter of the next). At a limit, above all of these: compound 2.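

Bromo in place of nitro on the six-membered aromatic ring of the core gives an at least 2.1-fold lower number from compound 2 to compound 4 (0.34 log units; beyond the scatter). Going by these compounds alone, the earlier nitro step stayed within the scatter, so this pair is the first to show a change that moves the number beyond it, and here the position is on the core. How large the step really is stays open, since compound 2 carries a limit and not a number: the limit of > 100000 nM in this assay, at which 1 of the 4 values shown sits.

From the compounds shown here alone, whether chloro or methoxy at this position would give a similar number remains open. So does the effect of a longer chain on the carbonyl.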